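A few compounds are considered here, and "the series" means these few. Any claim that something is new, unique, unknown or untested is made for them only; others in the source may bear on it.

In an ADME assay on Vero cells (Chlorocebus sabaeus) for cytotoxicity, read by neutral red uptake, tested at 394 ug/mL (on this read-out lower numbers stand for a stronger effect and higher numbers for a weaker effect at the one concentration tested), compound 1 `O=C1CSC(c2cccc(Cl)c2)N1CCN1CCCCC1` gives 45% and compound 2 `O=C1CSC(c2cccc(F)c2)N1CCN1CCCCC1` gives 60%. For the measured compounds named here, the one step so far is a number 15 percentage points higher from compound 1 to compound 2 (beyond the scatter). Compound 2 thus stands highest of the two numbers. Compound 3 `COc1cccc(C2SCC(=O)N2CCN2CCCCC2)c1` carries methoxy in place of fluoro on an aromatic carbon. Going by the values given here, no measured step exchanges fluoro for methoxy on an aromatic carbon; the only known step, from compound 1 to compound 2, was modest and upward. Without a direct precedent, a step expected to stay within the scatter is assumed, no change at the digits printed from compound 2 to compound 3 (within the scatter). Compound 3 is therefore estimated at 60%, with a range from 40% to 80%.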

Compound 3, a percentage reported as activity, at one concentration (the size of the read-out at that concentration, not a potency): 57%
Compound 3: middle estimate off by 3 percentage points, on the high side, and the stated range covers the measured number.
By their numbers in this assay, from the lowest: compound 1; then compounds 3 and 2 (each within the scatter of the next).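

In this assay, methoxy in place of fluoro on this aromatic carbon, meta to a large group, gives (a number 3 percentage points lower from compound 2 to compound 3 (within the scatter)), so the larger group with its hydrogen-bond acceptor reads the same as the single fluorine. Methoxy in place of chloro gives (a number 12 percentage points higher from compound 1 to compound 3 (beyond the scatter)), which leaves compound 1 as the one apart among the three. No measured property bears on these readings. On these data alone, what an amine or a carboxylic acid on this carbon would give stays open. As far as these compounds go, whether the chloro gap holds for a bromo group is also open.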